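The source may report more compounds than this note shows. Statements on the series, on what has been measured and on what is new or still open speak of the compounds shown alone.

Three compounds share one core and differ only in the group carried on a chain from the ring amine. Compound 1 `COc1ccc(OCCCCCN2CCCC(COC(=O)c3ccccc3N3C(=O)CC(C)C3=O)C2)cc1OC` gives 8320 nM in an in vitro functional assay on HEK ts201 cells for antagonist activity at Neuronal acetylcholine receptor; alpha4/beta2 (Homo sapiens), read by fluorescence and calcium flux; a lower number here means a stronger inhibitor, a higher number a weaker inhibitor. Compound 2 `CC1CC(=O)N(c2ccccc2C(=O)OCC2CCCN(CCCCOc3ccccc3)C2)C1=O` gives 1700 nM in this assay, and compound 3 `CC1CC(=O)N(c2ccccc2C(=O)OCC2CCCN(CCCC3CCCCC3)C2)C1=O` gives 14500 nM in this assay. Compound 3 thus stands with the highest number of the three, close to compound 1 and far from compound 2.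

Compound 4 `COc1ccc(OCCCCCN2CCCC(COC(=O)c3ccccc3N3C(=O)CC(C)C3=O)C2)cc1` has not yet been measured. It differs from compound 3 in one place: 2-(4-methoxyphenoxy)ethyl in place of cyclohexyl on a saturated chain carbon, three bonds along the chain from an amine nitrogen in a ring. Among the compounds with values here, two measured steps bear on this change. Replacing the phenoxymethyl group with cyclohexyl gave an 8.5-fold higher number from compound 2 to compound 3 (0.93 log units; beyond the scatter), so going back toward an aryl ether on the chain should move the number the other way. Trimming two methoxy groups and a chain carbon gave a 4.9-fold lower number from compound 1 to compound 2 (0.69 log units; beyond the scatter), and compound 4 sits between compound 1 and compound 2 in that respect. A lower number is therefore expected for compound 4, of about a 4.1-fold lower number from compound 3 to compound 4 (0.62 log units; beyond the scatter). The estimate for compound 4 in this assay is 3500 nM, with a range from 1200 nM to 9000 nM.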

Compound 4, half-maximal inhibitory concentration: 14500 nM
Compound 4: middle estimate off by 4.1-fold (0.62 log units), on the low side; the whole stated range lies below it.
By their numbers in this assay, from the lowest: compound 2; then compounds 1, 3 and 4 (each within the scatter of the next).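

In this assay, putting 2-(4-methoxyphenoxy)ethyl in place of cyclohexyl gave no change at the digits printed from compound 3 to compound 4 (within the scatter), so at this position, among these compounds, an aromatic ring and ether oxygens on the chain do not by themselves give a lower number than a plain cyclohexyl. Compound 2 stays apart, with an 8.5-fold higher number from compound 2 to compound 4 (0.93 log units; beyond the scatter), whereas removing one methoxy from the aromatic ring gave a 1.7-fold higher number from compound 1 to compound 4 (0.24 log units; within the scatter), so that methoxy makes no difference beyond the scatter on this longer chain. No measured evidence here explains these results.

On these data alone, the step from compound 2 changes both chain length and the methoxy group, so their separate shares remain unknown. Also open, as far as these compounds go, is whether a plain phenoxy on the longer chain of compound 4, or a chain ending in a carboxylic acid, would fall nearer compound 2.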